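Aryl swap on the amine nitrogen: compound 2 to compound 4

The source may hold more compounds than are shown below. What is called first, only, known or untested is meant among the compounds shown, and "the series" means these compounds.

Measured so far:
- compound 1, `Cc1ccc(Nc2cc(NC(=O)Nc3c(Cl)cccc3Cl)ncn2)cc1F`: 33.5%
- compound 2, `COc1cc(NC(=O)Nc2cc(Nc3ccc(C)c(F)c3)ncn2)cc(OC)c1`: 30.6%
- compound 3, `CCc1ccc(Nc2cc(NC(=O)Nc3c(Cl)cccc3Cl)ncn2)cc1`: 31.5%

In a functional assay on NCI-H520 cells (Homo sapiens) for inhibition, read by MTT assay, with a stated time of 48 h, tested at 10 uM (a higher number here means more inhibition at the concentration tested (going by the name of the read-out), a lower number less inhibition), compound 2 gives 30.6%, the lowest of the three numbers, but its gaps to compound 3 and to compound 1 are both within the scatter, so the three compounds are not separated by this read-out.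

Compound 4, `COc1cc(NC(=O)Nc2cc(Nc3cc(C)cc(F)c3)ncn2)cc(OC)c1`, has not been measured. It differs from compound 2 in one place: 3-fluoro-5-methylphenyl in place of 3-fluoro-4-methylphenyl on a nitrogen on an aromatic ring.

For the measured compounds named here, one measured step bears on this. It is also an exchange of the aryl group on the same nitrogen, and it gave a number 2 percentage points lower from compound 1 to compound 3 (within the scatter). That step moved the number by less than the scatter, so a change of the aryl group at this position has so far left the read-out unchanged within the assay's noise.

The expectation is therefore that the step from compound 2 to compound 4 amounts to a number 0.4 percentage points higher from compound 2 to compound 4 (within the scatter), with no shift beyond the scatter. Compound 4 is estimated at 31%, in the range 21% to 41%.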

Compound 4, a percentage reported as inhibition, at one concentration (the size of the read-out at that concentration, not a potency): 24.5%
Compound 4: the middle estimate sits 6.5 percentage points above what was measured, within the range that was stated.
By their numbers in this assay, from the lowest: compounds 4, 2, 3 and 1 (each within the scatter of the next).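

For the compounds shown here, compound 2 and compound 4 hold the same atoms, so this is the first change at the nitrogen that only rearranges the aryl substituents, and in this assay it gives a number 6.1 percentage points lower from compound 2 to compound 4 (within the scatter). Like the exchange that gives a number 2 percentage points lower from compound 1 to compound 3 (within the scatter), this rearrangement does not separate the compounds, so neither a change of aryl group nor a change in how 3-fluoro-4-methylphenyl is substituted has yet moved the read-out beyond the noise at this position. No independent data bear on this result.

Still open, from the compounds shown here alone, is whether an aryl group carrying an amine or a carboxylic acid, or a pyridine ring in place of the phenyl, would shift the read-out at this nitrogen beyond the scatter. Also open, going by these compounds, is whether compound 2 and compound 4 would differ in a full concentration-response potency, which a single-concentration read-out cannot show.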